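Methoxy for methylsulfonyl on the pendant phenyl ring

The source may hold more compounds than are shown below. What is called first, only, known or untested is meant among the compounds shown, and "the series" means these compounds.

Two compounds of this series have been examined in an ADME assay on HeLa cells (Homo sapiens) for cytotoxicity, read by ATP content, with a stated time of 3 days; a higher number here means that more compound is tolerated, a lower number that less compound is tolerated. Compound 1, `O=c1n(Cc2cc3cnccc3n2CCCCF)c2cnccc2n1C1CC1`, reaches only the limit of the assay, giving > 50000 nM. Compound 2, `CS(=O)(=O)c1ccc(-n2c(=O)n(Cc3cc4cc(Cl)ccc4n3CCCC#N)c3cnccc32)cc1`, likewise gives > 50000 nM, which is a limit and not a number. For the measured compounds named here, no step between two measured compounds can be read from these two, so the series shows only (the limit of > 50000 nM in this assay, at which 2 of the 2 values shown sit). Compound 3, `COc1ccc(-n2c(=O)n(Cc3cc4cc(Cl)ccc4n3CCCC#N)c3cnccc32)cc1`, carries the change (methoxy in place of methylsulfonyl on an aromatic carbon), that is, methoxy in place of methylsulfonyl on an aromatic carbon of the phenyl ring that hangs from the shared core. Nothing measured here points in either direction, so the step from compound 2 to compound 3 is expected to stay within the scatter of this assay, most probably as a repeat of the limit. Compound 3 is therefore expected to give 50000 nM, with a range from 20000 nM to 100000 nM, which corresponds to a step of a number no higher from compound 2 to compound 3 (the limit leaves the size open).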

Compound 3, half-maximal cytotoxic concentration: > 50000 nM
Compound 3: only a limit was reported (the forecaster's own chance of this, stated with the estimate: 75%); the middle value lies on the limit itself.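

Compound 2 and compound 3 are both reported only as limits, so no step can be read between them. Left open is whether methoxy in place of methylsulfonyl changes the tolerated concentration at all, and where the true values of the three compounds lie: the limit of > 50000 nM in this assay, at which 3 of the 3 values shown sit.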